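The source may report more compounds than this note shows. Statements on the series, on what has been measured and on what is new or still open speak of the compounds shown alone.

Measured compounds:
Compound 1 `C#CCn1cc(C(=O)NC(CC(=O)Nc2ccccn2)c2ccccc2)c(=O)c2ccc(Cl)nc21`: in a functional assay on MIA PaCa-2 cells (Homo sapiens) for cytotoxicity, read by MTT assay, with a stated time of 72 h (on this read-out lower numbers stand for stronger inhibition and higher numbers for weaker inhibition), compound 1 gives > 10000 nM, which is a limit of the assay.
Compound 2 `C#CCn1cc(C(=O)NC(CC(=O)Nc2ccccc2)c2ccccc2)c(=O)c2ccc(Cl)nc21`: in this assay compound 2 gives 3000 nM.

Among the measured compounds shown here, compound 2 carries the only numerical value in this assay; the other entry is a limit, as the limit of > 10000 nM in this assay, at which 1 of the 2 values shown sits, records. For the measured compounds named here, the single measured step, an at least 3.3-fold lower number from compound 1 to compound 2 (0.52 log units; beyond the scatter), puts phenyl in place of pyridin-2-yl on the amide-type nitrogen and lies beyond the scatter.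

Compound 3 `C#CCn1cc(C(=O)NC(CC(=O)NC2CCCC2)c2ccccc2)c(=O)c2ccc(Cl)nc21` differs from compound 2 by cyclopentyl in place of phenyl on an amide-type nitrogen. The measured step touches the same amide-type nitrogen, but it exchanges one six-membered aromatic ring for another, whereas the move to cyclopentyl brings a five-membered non-aromatic ring; that step therefore gives no direction for this change. The pair of compounds 1 and 2 shows only that the substituent at this position matters. Compound 3 is expected to stay within the scatter of the measured number, a step of a 1.3-fold higher number from compound 2 to compound 3 (0.12 log units; within the scatter). Compound 3 is estimated at 4000 nM, between 1000 nM and 15000 nM, with a real chance that the assay reports only a limit.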

Compound 3, half-maximal inhibitory concentration: 2400 nM
Estimate against measurement, compound 3: 1.7-fold (0.22 log units) above, and the stated range covers the measured number.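

In this assay, cyclopentyl in place of phenyl on the amide-type nitrogen gives a 1.3-fold lower number from compound 2 to compound 3 (0.10 log units; within the scatter), so a five-membered non-aromatic ring of carbon only and a six-membered aromatic ring of carbon only cannot be told apart at this position. Cyclopentyl in place of pyridin-2-yl gives an at least 4.1-fold lower number from compound 1 to compound 3 (0.61 log units; beyond the scatter), so the separation first seen with phenyl also appears with a non-aromatic ring, and among the three compounds only compound 1 stands apart. Compound 1 sits at a limit of the assay, so the full size of both steps from it stays unknown: the limit of > 10000 nM in this assay, at which 1 of the 3 values shown sits.

Still open, as far as these compounds go, is whether any ring is needed on this nitrogen, a question that a methyl group or a longer chain would address, and whether the weak result of compound 1 is tied to the ring nitrogen of pyridin-2-yl or would also hold for pyridin-3-yl. From the compounds shown here alone, how an amine or a carboxylic acid on the cyclopentyl ring would read in this assay also remains open.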